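The compounds below may be only part of what the source reports. "The series", "measured", "known", "first", "only" and "open" are said of these compounds alone.

Measured so far in a functional assay on HeLa cells (Homo sapiens) for inhibition, read by MTT assay, with a stated time of 72 h; a lower number here means a stronger inhibitor, a higher number a weaker inhibitor:
Compound 1 `COc1ccc(/C=C/C(=O)c2c(OC)cc(O)c(CC=C(C)C)c2O)cc1` gives > 50000 nM.
Compound 2 `COc1ccccc1/C=C/C(=O)c1c(OC)cc(O)c(CC=C(C)C)c1O` gives 19700 nM.
Compound 3 `COc1ccc(/C=C/C(=O)c2c(O)cc(O)cc2OC)cc1` gives 47700 nM.

The value of compound 1 is a limit of the assay, not a number (the limit of > 50000 nM in this assay, at which 1 of the 3 values shown sits).

The core of compound 2 differs from that of compound 1 by 2-methoxyphenyl in place of 4-methoxyphenyl on a double-bonded chain carbon bound to a double-bonded chain carbon, and this gives an at least 2.5-fold lower number from compound 1 to compound 2 (0.40 log units; beyond the scatter). Compound 3 arises from compound 1 through (hydrogen in place of 3-methylbut-2-en-1-yl on an aromatic carbon), with an at least 1.0-fold lower number from compound 1 to compound 3 (0.02 log units; that floor lies within the scatter).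

Compound 4 `COc1ccccc1/C=C/C(=O)c1c(O)cc(O)cc1OC`, not yet measured, arises from compound 2 through (hydrogen in place of 3-methylbut-2-en-1-yl on an aromatic carbon). The surroundings of the place read the same as for compound 3, so the change is the same. For the measured compounds named here, compound 4 is expected to sit close to compound 2, a step of about a 1.3-fold higher number from compound 2 to compound 4 (0.10 log units; within the scatter) in this assay, resting on the only earlier instance, the step from compound 1 to compound 3 an at least 1.0-fold lower number from compound 1 to compound 3 (0.02 log units; that floor lies within the scatter), whose floor lies within the scatter. Compound 4 is estimated at 25000 nM, between 10000 nM and 60000 nM.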

Compound 4, half-maximal inhibitory concentration: 43600 nM
Compound 4: middle estimate off by 1.7-fold (0.24 log units), on the low side; low and high end bracket the measured number.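

In this assay, hydrogen in place of 3-methylbut-2-en-1-yl on the core of compound 2 leaves a weaker inhibitor, with a 2.2-fold higher number from compound 2 to compound 4 (0.35 log units; beyond the scatter). Set beside the earlier instance, the change cannot be called the same or different on the two cores: the same change on two cores in this assay, an at least 1.0-fold lower number (0.02 log units; that floor lies within the scatter) from compound 1 to compound 3 and a 2.2-fold higher number (0.35 log units; beyond the scatter) from compound 2 to compound 4; the limit leaves it open whether they differ. Compound 1 gives > 50000 nM, a limit of the assay and not a number, so the size of the step on its core stays unfixed and this pair neither confirms nor rules out carrying the change across cores.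

Only 3-methylbut-2-en-1-yl and hydrogen appear on this aromatic carbon in the compounds shown. On these data alone, how a longer chain or an amine there would read in this assay stays open, as does the size of the change on any third core.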